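This account rests on a few compounds, and the source may have more. Where it says the series, first, only, none or still open, it means among the compounds named here.

Measured so far:
- compound 1, `O=c1cc(/C=C/c2ccc(O)cc2)oc2cc(O)cc(O)c12`: 8500 nM
- compound 2, `O=c1cc(/C=C/c2ccccc2)oc2cc(O)ccc12`: 72300 nM

In a functional assay (on this read-out lower numbers stand for stronger inhibition and higher numbers for weaker inhibition), compound 1 gives 8500 nM, the lowest of the two numbers recorded. Compound 2 gives 72300 nM in the same assay; the gap between these two values lies beyond the scatter, but the two structures differ in more than one place, so no single step can be read from them.

Compound 3, `O=c1cc(/C=C/c2ccc(O)c(O)c2)oc2cc(O)cc(O)c12`, is not yet measured in this assay. It differs from compound 1 by hydroxy in place of hydrogen on an aromatic carbon. The hydroxy enters on an aromatic carbon of a six-membered aromatic ring of carbon only, ortho to a hydroxy group and meta to a large group. Among the measured compounds shown here, no pair of measured compounds shows this change, so the size of the step must be guessed from the change alone; a small step toward stronger inhibition, or none beyond the scatter, is expected, written as a 1.4-fold lower number from compound 1 to compound 3 (0.15 log units; within the scatter). Compound 3 is therefore estimated at 6000 nM, with a range from 2000 nM to 18000 nM.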

Compound 3, half-maximal inhibitory concentration: 3900 nM
The estimate for compound 3 lay 1.5-fold (0.19 log units) above the measured number; the range from low to high includes it.
By their numbers in this assay, from the lowest: compound 3; then compound 1; then compound 2.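

Hydroxy in place of hydrogen on an aromatic carbon, ortho to a hydroxy group and meta to a large group, gives in this assay a 2.2-fold lower number from compound 1 to compound 3 (0.34 log units; beyond the scatter), a modest step toward stronger inhibition. Among the compounds shown here, this is the first change that can be read at a single place, as compound 1 and compound 2 differ in more than one place and gave no step. The place therefore accepts a hydroxy without loss in this assay and with a small gain, but nothing measured on these compounds accounts for that gain.

As far as these compounds go, it remains open whether the gain belongs to the hydroxy itself or would also appear with another group at the same place, such as a methoxy group, an amine or a fluorine atom. A single step also cannot show whether the hydroxy already present in compound 1 contributes to the value, or whether the same change would give a step of similar size elsewhere on the core.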